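Compound 3 to compound 4: butoxy for diethylamino

A few compounds are considered here, and "the series" means these few. Any claim that something is new, unique, unknown or untested is made for them only; others in the source may bear on it.

In an ADME assay on cells (Fibroblast, Homo sapiens) for antiproliferative activity, with a stated time of 48 h (a higher number here means a weaker inhibitor, a lower number a stronger inhibitor), compound 1 `CCN(CC)c1ccc(-c2ccc(C#N)cc2)nn1` gives > 25000 nM, which is a limit of the assay. Compound 2 `CCN(CC)c1ccc(-c2ccc(C(=O)O)cc2)nn1` gives > 25000 nM, also a limit. Among the compounds with values here, compound 3 `CCOC(=O)c1ccc(-c2ccc(N(CC)CC)nn2)cc1` gives 3000 nM, the only true number so far. The measured steps, an at least 8.3-fold lower number from compound 1 to compound 3 (0.92 log units; beyond the scatter) and an at least 8.3-fold lower number from compound 2 to compound 3 (0.92 log units; beyond the scatter), both concern the ethoxycarbonyl group. Compound 4 `CCCCOc1ccc(-c2ccc(C(=O)OCC)cc2)nn1` keeps that group and differs at another place: butoxy in place of diethylamino on an aromatic carbon. Within the data shown here, no measured step covers this change, so neither size carries over, and the value of compound 3 at 3000 nM is the only anchor. For compound 4 the expected step is a 1.3-fold higher number from compound 3 to compound 4 (0.12 log units; within the scatter), with no clear direction beyond the scatter. The estimated value for compound 4 is 4000 nM, within a range of 1200 nM to 20000 nM.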

Compound 4, half-maximal inhibitory concentration: > 25000 nM
Compound 4: only a limit was reported (the forecaster's own chance of this, stated with the estimate: 15%); middle value at least 6.2-fold (0.79 log units) from the limit.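

Where the earlier steps concerned only the ethoxycarbonyl group, this one shows that the position on the other side of the shared core also matters in this assay: butoxy in place of diethylamino gives an at least 8.3-fold higher number from compound 3 to compound 4 (0.92 log units; beyond the scatter). Keeping the ethoxycarbonyl group is thus not sufficient on its own, even though both groups count the same heavy atoms. Compound 4 gives only a limit of the assay, so the full size of the step cannot be read: the limit of > 25000 nM in this assay, at which 3 of the 4 values shown sit.

From the compounds shown here alone, whether the nitrogen attached at this position is what counts remains open. A dimethylamino group, a cyclic amine such as piperidine, or a shorter ether such as methoxy would test this.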